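A Single Ring Swap on a Weakly Cytotoxic Compound

The source may report more compounds than this note shows. Statements on the series, on what has been measured and on what is new or still open speak of the compounds shown alone.

In a functional assay on PC-3 cells (Homo sapiens) for cytotoxicity, read by colorimetric assay and MTT assay (on this read-out higher numbers stand for weaker inhibition and lower numbers for stronger inhibition), compound 1 (`COc1ccc(-c2cc3c(OC)cc(OC)cc3n(CCC#N)c2=O)cc1`) gives 10000 nM. Compound 2 (`COc1ccc(-c2cc3c(OC)cc(OC)cc3n(C)/c2=N\Nc2ccccc2)cc1`) gives 10000 nM, the same figure, so it stands level with compound 1. Compound 3 (`COc1ccc(-c2cc3c(OC)cc(OC)cc3n(C)/c2=N\Nc2ccccn2)cc1`) differs from compound 2 in one place: pyridin-2-yl in place of phenyl on an amine nitrogen. Within the data shown here, no measured pair yet shows what this swap does, so any forecast is uncertain. A small move toward stronger inhibition, close to the scatter, is expected, and the estimated step is a 2.0-fold lower number from compound 2 to compound 3 (0.30 log units; within the scatter). For compound 3 the estimated value is 5000 nM, within a range from 1000 nM to 12000 nM.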

Compound 3, half-maximal inhibitory concentration: 10000 nM
Estimate against measurement, compound 3: 2.0-fold (0.30 log units) below; measured number inside the range.
By their numbers in this assay, from the lowest: compounds 1, 2 and 3 (each within the scatter of the next).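

Pyridin-2-yl in place of phenyl on the amine nitrogen gives no change at the digits printed from compound 2 to compound 3 (within the scatter) in this assay at this place. Exchanging a ring carbon for nitrogen, which adds one hydrogen-bond acceptor at the same heavy-atom count, therefore leaves the number where it was. Nothing measured here explains this result.

Compounds 1, 2 and 3 all print the same figure, so none of them shows what could shift this number. As far as these compounds go, whether a benzoyl group or a simple alkyl chain on this amine nitrogen would do so remains open.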